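The compounds below may be only part of what the source reports. "The series", "measured", "known", "first", "only" and "open" are said of these compounds alone.

Working notes on the series. Compound 1 `CCCCC[Se]c1nc([Se]CCCCC)c2ccccc2n1` is the reference point. In a functional assay on HT-29 cells (Homo sapiens) for cytotoxicity, read by MTT assay, with a stated time of 72 h (a lower number here means that less compound is tolerated, a higher number that more compound is tolerated), compound 1 reaches only a limit, > 100000 nM. Compound 2 `Sc1nc(NCc2ccccc2)c2ccccc2n1` likewise reaches only a limit in this assay, > 100000 nM. For compound 3 `[SeH]c1nc([SeH])c2cccnc2n1` the entry in this assay is "not determined" (no result reported). Among the numbers shown, compound 1 sits at the limit of > 100000 nM in this assay, at which 2 of the 3 values shown sit. Among the compounds with values here, no step between measured compounds is available. Compound 4 `CCCCC[Se]c1nc(N)c2ccccc2n1` differs from compound 1 by one nitrogen atom in place of a group of 6 heavy atoms (5 carbon, 1 selenium; no ring), on an aromatic carbon. In this assay no step beyond the scatter is expected in either direction. Compound 4 is expected at 100000 nM, between 30000 nM and 300000 nM. This amounts to an expected a number no higher from compound 1 to compound 4 (the limit leaves the size open).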

Compound 4, concentration lethal to 50% of the cells: > 100000 nM
Compound 4: only a limit was reported; the forecaster's own chance of this, stated with the estimate: 70%; the middle value sits exactly at the limit.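

Compound 1 and compound 4 both reach only a limit in this assay, so no step between them can be read: the limit of > 100000 nM in this assay, at which 3 of the 4 values shown sit.

The compounds shown leave open what size of change, if any, the amino group brings in this assay.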